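The source may hold more compounds than are shown below. What is called first, only, known or untested is meant among the compounds shown, and "the series" means these compounds.

Measured compounds in a functional assay on DLD-1 cells (Homo sapiens) for antiproliferative activity, read by CellTiter-Glo, with a stated time of 72 h; on this read-out higher numbers stand for weaker inhibition and lower numbers for stronger inhibition:
- compound 1 `CC1CCN(C2CCN(S(=O)(=O)c3ccc(C#N)cc3)CC2)CC1` gives 2800 nM
- compound 2 `Cc1cccc(S(=O)(=O)N2CCC(N3CCC(C)CC3)CC2)c1` gives 25 nM
- compound 3 `CC1CCN(C2CCN(S(=O)(=O)c3cccc(Cl)c3)CC2)CC1` gives > 5000 nM

Compound 3 sits at the limit of this assay, (the limit of > 5000 nM in this assay, at which 1 of the 3 values shown sits), so it yields no number. Of the two numbers, compound 1 has the higher: the step of a 110-fold lower number from compound 1 to compound 2 (2.05 log units; beyond the scatter) is large, and the step of an at least 200-fold higher number from compound 2 to compound 3 (2.30 log units; beyond the scatter) runs the same way. The step of an at least 1.7-fold higher number from compound 1 to compound 3 (0.25 log units; that floor lies within the scatter) is a floor that lies within the scatter.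

The unmeasured compound 4 is `CC1CCN(C2CCN(S(=O)(=O)c3ccc(-c4ccc(Cl)cc4)cc3)CC2)CC1`. It differs from compound 1 in one place: 4-chlorophenyl in place of cyano on an aromatic carbon. Among the measured compounds shown here, none of the measured steps changes the group at that position alone; the measured steps swap the whole aryl group on the sulfonyl sulfur or swap chloro for methyl. Each of them shows the shared core to be sensitive to changes on that aryl ring, two of them by a large margin. The direction of the step to compound 4 therefore cannot be read from the measured compounds, and the expectation is wide. Compound 4 is expected at 3000 nM, between 500 nM and 15000 nM. The expected step is a 1.1-fold higher number from compound 1 to compound 4 (0.03 log units; within the scatter).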

Compound 4, half-maximal inhibitory concentration: 105 nM
Beside the measured number, compound 4's estimate is 29-fold (1.46 log units) above it; measured number outside the range, below it.
By their numbers in this assay, from the lowest: compound 2; then compound 4; then compound 1. At a limit, above all of these: compound 3.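

Among the compounds shown here, compound 1 to compound 4 is the first step that changes the group at this position alone, whereas the earlier steps swapped the whole aryl group or exchanged chloro for methyl. In this assay, the step gives a 27-fold lower number from compound 1 to compound 4 (1.43 log units; beyond the scatter), so this position accepts the larger 4-chlorophenyl, with its added aromatic ring, in place of cyano, and inhibition grows stronger by a large margin. Nothing shown gives a reason for this step.

The compounds shown leave open whether the added ring alone carries the change or the chloro on it also contributes, a question that a plain phenyl at this position would address. Also open, as far as these compounds go, is whether a ring is needed at all, or whether a small group such as methyl or a longer alkyl chain would serve here.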